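Lengthening the acid chain on a tetrahydroisoquinoline amide

A few compounds are considered here, and "the series" means these few. Any claim that something is new, unique, unknown or untested is made for them only; others in the source may bear on it.

Measured compounds:
compound 1 `O=C(O)CN1Cc2ccc(NC(=O)CCCC3CCNCC3)cc2C1=O`, 66000 nM
compound 2 `O=C(O)CN1Cc2ccc(NC(=O)c3ccc4c(c3)CNCC4)cc2C1=O`, 120000 nM
compound 3 `O=C(O)CCN1Cc2ccc(NC(=O)c3ccc(N4CCNCC4)cc3)cc2C1=O`, 540 nM

In a functional assay on a cell-free system (Platelet, plasma, Homo sapiens) for inhibition (on this read-out higher numbers stand for weaker inhibition and lower numbers for stronger inhibition), compound 2 gives 120000 nM, the highest of the three numbers. Compound 1 gives 66000 nM, a number within the scatter of compound 2. Compound 3 gives 540 nM, far below both.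

Compound 4 `O=C(O)CCN1Cc2ccc(NC(=O)c3ccc4c(c3)CNCC4)cc2C1=O` is not yet measured. It differs from compound 2 in one place: carboxymethyl in place of carboxy on a saturated chain carbon bound to an amide-type nitrogen in a ring. For the measured compounds named here, no measured pair shows this change on its own; compound 3 carries the longer chain but differs elsewhere as well, so its number cannot be credited to the chain alone.

The step from compound 2 to compound 4 is expected to go toward lower numbers, beyond the scatter, as an 8.0-fold lower number from compound 2 to compound 4 (0.90 log units; beyond the scatter). Compound 4 is estimated at 15000 nM, within 2000 nM to 100000 nM.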

Compound 4, half-maximal inhibitory concentration: 1100 nM
Compound 4: middle estimate off by 14-fold (1.13 log units), on the high side; the whole stated range lies above it.
By their numbers in this assay, from the lowest: compound 3; then compound 4; then compounds 1 and 2 (each within the scatter of the next).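

Placing carboxymethyl where carboxy stood, on a saturated chain carbon bound to an amide-type nitrogen in a ring, gives a 110-fold lower number from compound 2 to compound 4 (2.04 log units; beyond the scatter) in this assay, with the rest of the molecule unchanged. For the compounds shown here, this pair is the first to show the change on its own, and it shows that this position responds strongly to one added chain carbon. Nothing available explains the size of this step.

Going by these compounds, whether a longer chain carrying the carboxylic acid would lower the number further remains open. So does whether the same change would act similarly on compound 1, with its piperidine-bearing amide.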